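A few compounds are considered here, and "the series" means these few. Any claim that something is new, unique, unknown or untested is made for them only; others in the source may bear on it.

Measured so far:
compound 1 `C=C(CC)C(=O)c1ccc(OCC(=O)Nc2ccc(C(=O)O)cn2)c(Cl)c1Cl` — 14900 nM
compound 2 `C=C(CC)C(=O)c1ccc(OCC(=O)Nc2ccc(CC(=O)O)cc2)c(Cl)c1Cl` — 3200 nM

In a functional assay on CLL cells (Homo sapiens) for cytotoxicity, read by MTT assay, with a stated time of 48 h (on this read-out lower numbers stand for an effect already at smaller amounts and higher numbers for an effect only at larger amounts of compound), compound 1 gives 14900 nM, the highest of the two numbers; compound 2 gives 3200 nM, a lower number by a gap beyond the scatter. Compound 3 `C=C(CC)C(=O)c1ccc(OCC(=O)NO)c(Cl)c1Cl` is not yet measured in this assay. It differs from compound 1 by hydroxy in place of 5-carboxypyridin-2-yl on an amide-type nitrogen. Among the compounds with values here, no measured pair differing in one place gives a step to lean on, so the size of this change is open. For compound 3 a modest shift towards lower numbers is expected, a 1.9-fold lower number from compound 1 to compound 3 (0.27 log units; within the scatter), though a result within the scatter of compound 1 would not surprise. Compound 3 is estimated at 8000 nM, range 2000 nM to 30000 nM.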

Compound 3, half-maximal effective concentration: 4500 nM
The estimate for compound 3 lay 1.8-fold (0.25 log units) above the measured number; measured number inside the range.
By their numbers in this assay, from the lowest: compounds 2 and 3 (each within the scatter of the next); then compound 1.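

In this assay, hydroxy in place of 5-carboxypyridin-2-yl on the amide-type nitrogen gives a 3.3-fold lower number from compound 1 to compound 3 (0.52 log units; beyond the scatter). The 5-carboxypyridin-2-yl group is therefore not required at this position for cytotoxicity, and a single oxygen-bearing group with no ring suffices to give the lower number. Nothing measured here accounts for this step. From the compounds shown here alone, it remains open whether the hydroxy itself matters, or whether a methoxy or an amine on this nitrogen would give a similar number.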